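The compounds below may be only part of what the source reports. "The series", "measured", "known", "first", "only" and "open" are said of these compounds alone.

Measured so far in an assay on a protein complex for positive allosteric modulation of Neuronal acetylcholine receptor; alpha4/beta2 (Homo sapiens); a lower number here means a smaller maximal response, a higher number a larger maximal response:
- compound 1 `Clc1ccccc1-c1cc(-c2cnn(C3CCNCC3)c2)on1`: 38%
- compound 2 `Cc1c(-c2cc(-c3ccccc3Cl)no2)cnn1C1CCNCC1`: 71%

Compound 1 holds the lowest of the two numbers in this assay. Going by the values given here, its only neighbour is compound 2, reached by methyl in place of hydrogen on an aromatic carbon, and that step, a number 33 percentage points higher from compound 1 to compound 2 (beyond the scatter), is beyond the scatter and large.

Compound 3 `Fc1cccc(Cl)c1-c1cc(-c2cnn(C3CCNCC3)c2)on1` is the next entry. The change from compound 1 is fluoro in place of hydrogen on an aromatic carbon, that is, 2-chlorophenyl to 2-chloro-6-fluorophenyl.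

Among the compounds with values here, no measured step covers this change. Within the data shown here, the single step known, from compound 1 to compound 2, is a methyl in place of hydrogen on an aromatic carbon and not a fluoro in place of hydrogen; it therefore gives no guide to the direction here, and only shows that a single small substituent can move the maximal response by a large amount. Without a step of the same kind, the expectation for compound 3 stays close to the value of compound 1, with a wide range. The expected step is a number 4 percentage points higher from compound 1 to compound 3 (within the scatter), within the scatter. Compound 3 is expected to give 42%, between 22% and 65%.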

Compound 3, largest response reached (reported as efficacy), in percent of the reference or control that the assay uses: 60%
For compound 3 the middle estimate is 18 percentage points below the measured one, and the stated range covers the measured number.
By their numbers in this assay, from the lowest: compound 1; then compound 3; then compound 2.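

In this assay the change from 2-chlorophenyl to 2-chloro-6-fluorophenyl gives a number 22 percentage points higher from compound 1 to compound 3 (beyond the scatter) and so shows that the maximal response also depends on this aromatic carbon, ortho to a large group and meta to the chloro group, and not only on the aromatic carbon that takes the methyl in compound 2. A substituent of a single heavy atom is enough to move the response here, and the earlier step, a number 33 percentage points higher from compound 1 to compound 2 (beyond the scatter) and likewise made from compound 1, has the same direction, so both single substitutions shown raise the number above that of compound 1. No measurement available here bears on why the fluoro group has this effect.

From the compounds shown here alone, whether the rise belongs to fluoro in particular or would also appear with a methoxy group or a nitrile at the same aromatic carbon remains open. Also open, going by these compounds, is whether the fluoro and methyl changes, placed together on the core of compound 1, would add up in this assay or would instead give a response no greater than either change alone.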